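Variation of the amide substituent on the shared core

This account rests on a few compounds, and the source may have more. Where it says the series, first, only, none or still open, it means among the compounds named here.

Compound 1 `COc1ccc(S(=O)(=O)N2CC(C(=O)NC3CCN(C)CC3)c3ccccc32)c2ccccc12` carries the shared core with the (1-methylpiperidin-4-yl)carbamoyl group. In a functional assay on CHO cells for antagonist activity at 5-hydroxytryptamine receptor 6 (Homo sapiens), read by FLIPR (a higher number here means a weaker inhibitor, a lower number a stronger inhibitor), compound 1 gives 25.1 nM, the lowest of the three numbers. Compound 2 `COc1ccc(S(=O)(=O)N2CC(C(=O)N3CC(CN)C3)c3ccccc32)c2ccccc12` gives 79.4 nM in this assay, and compound 3 `COc1cccc(N2CCN(C(=O)C3CN(S(=O)(=O)c4ccc(OC)c5ccccc45)c4ccccc43)CC2)c1` gives 63.1 nM. Among the measured compounds shown here, the only single-point step measured so far is a 3.2-fold higher number from compound 1 to compound 2 (0.50 log units; beyond the scatter), which changes the group on the carbonyl carbon and weakens inhibition modestly.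

Compound 4 `CCN(CC)CCNC(=O)C1CN(S(=O)(=O)c2ccc(OC)c3ccccc23)c2ccccc21` is not yet measured. It differs from compound 1 as follows: 2-(diethylamino)ethyl in place of 1-methylpiperidin-4-yl on an amide-type nitrogen. The step from compound 1 to compound 2 is the one that bears on it, since it also alters the amide substituent while keeping the rest of compound 1; that step was modest and pointed to a higher number. The change to compound 4 keeps the same count of heavy atoms and the same single acceptor, so a smaller shift, if any, is expected, with a higher number slightly more likely than a lower one. Compound 4 is therefore estimated at 40 nM in this assay, within 15 nM to 120 nM, the expected step being a 1.6-fold higher number from compound 1 to compound 4 (0.20 log units; within the scatter).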

Compound 4, inhibition constant: 20 nM
Compound 4: middle estimate off by 2.0-fold (0.30 log units), on the high side, within the range that was stated.
By their numbers in this assay, from the lowest: compounds 4 and 1 (each within the scatter of the next); then compounds 3 and 2 (each within the scatter of the next).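

In this assay, the ring of 1-methylpiperidin-4-yl gives way to the open 2-(diethylamino)ethyl on the amide-type nitrogen with no shift beyond the scatter (a 1.3-fold lower number from compound 1 to compound 4 (0.10 log units; within the scatter)), so within this pair the ring is not needed to hold the number. Against compound 2 the same chain gives a clear gain (a 4.0-fold lower number from compound 2 to compound 4 (0.60 log units; beyond the scatter)), but that step replaces the whole 3-(aminomethyl)azetidin-1-yl group on the carbonyl carbon and cannot be assigned to any one part of it. No measurement in hand accounts for either step.

Open, going by these compounds, is whether the nitrogen of the chain matters at all, which an all-carbon hexyl chain or a carboxylic acid on the amide-type nitrogen would test. Also open, on these data alone, is how far a longer chain ending in the same diethylamino group would be tolerated.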